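Adding a methyl to the coumarin core of compound 1

The source may hold more compounds than are shown below. What is called first, only, known or untested is meant among the compounds shown, and "the series" means these compounds.

Of the compounds shown here, three have been tested in a functional assay on B16-F10 cells (Mus musculus) for cytotoxicity, read by CCK-8 assay, with a stated time of 48 h; on this read-out higher numbers stand for weaker inhibition and lower numbers for stronger inhibition. Compound 1 `NS(=O)(=O)c1ccc(/N=C/c2c(Cl)c3ccccc3oc2=O)cc1` carries a free sulfonamide; in this assay compound 1 gives 300 nM. Compound 3 `Cc1ccnc(NS(=O)(=O)c2ccc(/N=C/c3c(Cl)c4ccccc4oc3=O)cc2)n1` carries a 4-methylpyrimidin-2-yl on the sulfonamide nitrogen and gives 230 nM. Compound 2 `Cc1cc(C)nc(NS(=O)(=O)c2ccc(/N=C/c3c(Cl)c4ccccc4oc3=O)cc2)n1` carries a 4,6-dimethylpyrimidin-2-yl there and gives 170 nM. All three numbers sit close together: a 1.8-fold lower number from compound 1 to compound 2 (0.25 log units; within the scatter), a 1.3-fold lower number from compound 1 to compound 3 (0.12 log units; within the scatter) and a 1.4-fold lower number from compound 3 to compound 2 (0.13 log units; within the scatter).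

The step from compound 3 to compound 2 is the one of interest here, namely (methyl in place of hydrogen on an aromatic carbon). The same kind of change appears between compound 1 and the unmeasured compound 4 `Cc1ccc2oc(=O)c(/C=N/c3ccc(S(N)(=O)=O)cc3)c(Cl)c2c1`: methyl in place of hydrogen on an aromatic carbon. The two cores differ as well, (hydrogen in place of 4-methylpyrimidin-2-yl on a sulfonamide nitrogen). The places are not the same: in compound 2 the methyl sits on a six-membered aromatic ring with 2 nitrogen, next to the ring nitrogen, meta to a large group, meta to a methyl group and opposite the ring nitrogen, while in compound 4 it sits on a six-membered aromatic ring of carbon only, part of a fused system of two rings, meta to a fused ring and para to a fused ring. So the change is the same kind, not the same.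

Because a 1.4-fold lower number from compound 3 to compound 2 (0.13 log units; within the scatter) stayed within the scatter, a similar small step is expected here, a 1.2-fold lower number from compound 1 to compound 4 (0.08 log units; within the scatter). Compound 4 is therefore estimated to give 250 nM in this assay, expected between 120 nM and 550 nM.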

Compound 4, half-maximal inhibitory concentration: 360 nM
For compound 4 the middle estimate is 1.4-fold (0.16 log units) below the measured one; the measured number falls inside the stated range.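

In this assay, a methyl in place of a hydrogen on an aromatic carbon of the core of compound 1 gives a 1.2-fold higher number from compound 1 to compound 4 (0.08 log units; within the scatter), so this step is small, and the number barely moves. Set beside the earlier step, the two cannot be told apart: the same change on two cores in this assay, a 1.4-fold lower number (0.13 log units; within the scatter) from compound 3 to compound 2 and a 1.2-fold higher number (0.08 log units; within the scatter) from compound 1 to compound 4, 1.6-fold (0.21 log units) apart, within the scatter of two such steps. This shows that in these two pairs the change left the number within the usual scatter on either core, but it does not show that a methyl behaves the same way wherever it is placed, for the methyl sits on a different ring in each pair and steps this small give no reliable direction.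

The compounds shown leave open whether a larger group in the same place on the ring of carbon only, such as an ethyl, a methoxy or a carboxylic acid, would move the number beyond the scatter. They also leave open what the same methyl does on that ring when the sulfonamide nitrogen carries a 4-methylpyrimidin-2-yl, which would test the same position on a second core directly.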